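The source may hold more compounds than are shown below. What is called first, only, known or untested is meant among the compounds shown, and "the series" means these compounds.

Measured so far in a functional assay on MIA PaCa-2 cells (Homo sapiens) for inhibition, read by MTT assay, with a stated time of 7 days; a higher number here means a weaker inhibitor, a lower number a stronger inhibitor:
- compound 1 `CC(C)c1noc(N2CCN(C(=O)[C@@H]3CCCN(S(=O)(=O)c4ccc(S(=O)(=O)C5CCC5)cc4)C3)CC2)n1`: 70 nM
- compound 2 `CCOC(=O)N1CCC[C@H](S(=O)(=O)c2ccc(S(=O)(=O)N(CC)CC)cc2)C1`: > 30000 nM, a limit of the assay
- compound 3 `CCOC(=O)[C@@H]1CCCN(S(=O)(=O)c2ccc(S(=O)(=O)N3CCNCC3)cc2)C1`: > 30000 nM, a limit of the assay

Going by the values given here, compound 1 carries the only numerical value in this set. For compound 2 the assay reports only a limit, > 30000 nM. For compound 3 the assay likewise reports only a limit, > 30000 nM. The evidence therefore reduces to the limit of > 30000 nM in this assay, at which 2 of the 3 values shown sit, and neither limit can be turned into a step against compound 1, since compound 2 and compound 3 each differ from it in more than one place; their values show only that neither reaches the measurable range.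

Compound 4 `CC(C)c1noc(N2CCN(C(=O)[C@@H]3CCCN(S(=O)(=O)c4ccc(S(=O)(=O)NC5CCC5)cc4)C3)CC2)n1` is the next analogue of compound 1. It differs in one place: cyclobutylamino in place of cyclobutyl on a sulfonyl sulfur, so that cyclobutylsulfonyl becomes cyclobutylsulfamoyl. Among the compounds with values here, no measured pair in the set isolates this change, so nothing quantifies it directly. The expectation is that the step of a 2.1-fold higher number from compound 1 to compound 4 (0.33 log units; beyond the scatter) stays small, a mild loss that may not exceed the usual scatter. Compound 4 is therefore estimated at 150 nM in this assay, with a plausible range from 40 nM to 600 nM.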

Compound 4, half-maximal inhibitory concentration: 600 nM
For compound 4 the middle estimate is 4.0-fold (0.60 log units) below the measured one; the measured number falls inside the stated range.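

In this assay, going by these compounds alone, replacing cyclobutyl with cyclobutylamino on a sulfonyl sulfur provides the first comparison that differs in one place only: an 8.6-fold higher number from compound 1 to compound 4 (0.93 log units; beyond the scatter). This position is therefore not indifferent to the change: with the rest of compound 1 held constant, the entering nitrogen and its hydrogen-bond donor accompany a loss beyond the scatter, although compound 4 still gives 600 nM, a measured number and not a limit. Nothing at hand bears on what underlies this step, so it stands as an observation only.

Within the data shown here, the single pair leaves open whether the loss follows the entering nitrogen or the hydrogen on it, a question that cyclobutyl(methyl)sulfamoyl on the same sulfonyl sulfur would address by keeping the nitrogen while replacing that hydrogen with a methyl group. It also leaves open how far the four-membered ring matters at this position, which cyclopentylsulfonyl or an open butylsulfonyl chain in place of cyclobutylsulfonyl would test against compound 1.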